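The source may hold more compounds than are shown below. What is called first, only, known or untested is meant among the compounds shown, and "the series" means these compounds.

Compound 1, `CCc1cn([C@H]2C[C@@H]3OP(=O)(O)OC[C@H]3O2)c(=O)[nH]c1=O`, is the reference point of this short series. In a functional assay on Raji cells (Homo sapiens) (on this read-out higher numbers stand for weaker inhibition and lower numbers for stronger inhibition), compound 1 gives > 500 ug/mL, which is a limit of the assay and not a number. Compound 2, `CCCc1cn([C@H]2C[C@@H]3OP(=O)(O)OC[C@H]3O2)c(=O)[nH]c1=O`, is its nearest measured neighbour. In this assay compound 2 gives > 500 ug/mL, again a limit. Among the measured compounds shown here, the only measured step, a step that the two limits leave unreadable from compound 1 to compound 2, therefore cannot be read in size or direction, since both of the values shown sit at the limit of > 500 ug/mL in this assay, at which 2 of the 2 values shown sit.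

The compound still to be measured is compound 3, `CCCCCc1cn([C@H]2C[C@@H]3OP(=O)(O)OC[C@H]3O2)c(=O)[nH]c1=O`. It differs from compound 1 by propyl in place of hydrogen on a saturated chain carbon, two bonds along the chain from an aromatic carbon. For the measured compounds named here, the one step that bears on this change is the lengthening from compound 1 to compound 2, which stayed unreadable, so there is no measured evidence for a move in either direction beyond the scatter. The expectation is accordingly that compound 3 will again return only a limit in this assay, and the step that the limit leaves unreadable from compound 1 to compound 3 is estimated as essentially flat. For compound 3 the estimate is 600 ug/mL, with a range from 250 ug/mL to 2000 ug/mL.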

Compound 3, concentration for 50% inhibition: > 500 ug/mL
Compound 3 ended at the assay's limit; the forecaster's own chance of this, stated with the estimate: 85%; the middle value lies beyond the limit too.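

The steps from compound 1 to compound 3 and from compound 2 to compound 3 cannot be read in this assay, since compound 3 also returns a limit and not a number: the limit of > 500 ug/mL in this assay, at which 3 of the 3 values shown sit.

The compounds shown leave open whether any chain at this place on the shared core gives a value that can be read as a number in this assay.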